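From 1,3-thiazol-2-yl to thiophen-2-yl on the shared core

The source may hold more compounds than are shown below. What is called first, only, known or untested is meant among the compounds shown, and "the series" means these compounds.

Measured values in a physicochemical assay for solubility, in phosphate buffer, with a stated time of 18 h (on this read-out higher numbers stand for higher solubility and lower numbers for lower solubility), are as follows
Compound 1 `CSc1nc(C(C)(C)C)nc2nc(N)c(C#N)c(N)c12` gives 14000 nM here
Compound 2 `CC(C)(C)c1nc(CCCCC#N)c2c(N)c(C#N)c(N)nc2n1` gives 16000 nM here
Compound 3 `CC(C)(C)c1nc(-c2nccs2)c2c(N)c(C#N)c(N)nc2n1` gives < 1500 nM here, a limit of the assay

Compound 3 thus stands at a limit and has no number of its own (the limit of < 1500 nM in this assay, at which 1 of the 3 values shown sits). Compound 4 `CC(C)(C)c1nc(-c2cccs2)c2c(N)c(C#N)c(N)nc2n1` carries thiophen-2-yl in place of 1,3-thiazol-2-yl on an aromatic carbon. The measured steps at this carbon are an at least 9.3-fold lower number from compound 1 to compound 3 (0.97 log units; beyond the scatter) and an at least 10-fold lower number from compound 2 to compound 3 (1.02 log units; beyond the scatter), both large and both ending at that limit, while a 1.1-fold higher number from compound 1 to compound 2 (0.06 log units; within the scatter) stays small. None of them exchanges one five-membered aromatic ring for another, and since such a ring both leaves and enters here, no step beyond the scatter is expected in this assay. The expected step is a step that the limit leaves unreadable from compound 3 to compound 4 in this estimate. For compound 4 the estimated value is 1000 nM, with an expected range of 350 nM to 3000 nM in this estimate.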

Compound 4, solubility: 56000 nM
Beside the measured number, compound 4's estimate is 56-fold (1.75 log units) below it; measured number above the stated range.
By their numbers in this assay, from the lowest: compounds 1 and 2 (each within the scatter of the next); then compound 4. At a limit, below all of these: compound 3.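

In this assay, thiophen-2-yl in place of 1,3-thiazol-2-yl on this aromatic carbon gives an at least 37-fold higher number from compound 3 to compound 4 (1.57 log units; beyond the scatter), so a five-membered aromatic ring here does not by itself go with a low number. Set against the open-chain and sulfur-linked groups, thiophen-2-yl gives a 3.5-fold higher number from compound 2 to compound 4 (0.54 log units; beyond the scatter) and a 4.0-fold higher number from compound 1 to compound 4 (0.60 log units; beyond the scatter), placing this ring above both. Compound 3 stands at a limit, so its step has no exact size: the limit of < 1500 nM in this assay, at which 1 of the 4 values shown sits.

From the compounds shown here alone, the exact value of compound 3 stays open. So does the place of other groups on this carbon, such as furan-2-yl, pyridin-2-yl or an amine.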